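Aryl Ether in Place of Methoxy in a Guanidine Series

The source may report more compounds than this note shows. Statements on the series, on what has been measured and on what is new or still open speak of the compounds shown alone.

Compound 3 `COc1cc(C)c(C(=O)N=C(N)N)cc1S(C)(=O)=O` gives 16 nM in a functional assay for inhibition of sodium/hydrogen exchanger (Oryctolagus cuniculus); on this read-out higher numbers stand for weaker inhibition and lower numbers for stronger inhibition. Among the three compounds measured it stands second highest; its nearest neighbour is compound 1 `Cc1cc(-c2ccccc2)c(S(C)(=O)=O)cc1C(=O)N=C(N)N`, which gives 19 nM, and its furthest is compound 2 `Cc1cc(Sc2ccncc2)c(S(C)(=O)=O)cc1C(=O)N=C(N)N`, which gives 13 nM, both within the scatter of compound 3. Compound 4 `Cc1cc(Oc2ccc(Cl)cc2)c(S(C)(=O)=O)cc1C(=O)N=C(N)N` differs from compound 3 by 4-chlorophenyl in place of methyl on an oxygen on an aromatic ring. Among the compounds with values here, two measured steps bear on this change: a 1.2-fold lower number from compound 1 to compound 3 (0.07 log units; within the scatter) and a 1.2-fold higher number from compound 2 to compound 3 (0.09 log units; within the scatter), each within the scatter, so the group at that place has made little difference across compounds 1, 2 and 3. For compound 4 the expected step is therefore a 1.1-fold lower number from compound 3 to compound 4 (0.03 log units; within the scatter). Compound 4 is estimated at 15 nM, within 6 nM to 40 nM.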

Compound 4, half-maximal inhibitory concentration: 13 nM
For compound 4 the middle estimate is 1.2-fold (0.06 log units) above the measured one; the range from low to high includes it.
By their numbers in this assay, from the lowest: compounds 2, 4, 3 and 1 (each within the scatter of the next).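

The swap of methyl for 4-chlorophenyl on the oxygen brings in a six-membered aromatic ring, yet the number stays within the scatter (a 1.2-fold lower number from compound 3 to compound 4 (0.09 log units; within the scatter)). At the aromatic carbon, 4-chlorophenoxy also stays within the scatter of the (pyridin-4-yl)sulfanyl group (no change at the digits printed from compound 2 to compound 4 (within the scatter)) and of phenyl (a 1.5-fold lower number from compound 1 to compound 4 (0.16 log units; within the scatter)), so all four groups shown now give comparable numbers at this place. No evidence is at hand that would account for this. On these data alone, whether any group here moves the number beyond the scatter stays open, for instance an amine or a carboxylic acid.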